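Shortening the Chain to the Reactive Arm

A few compounds are considered here, and "the series" means these few. Any claim that something is new, unique, unknown or untested is made for them only; others in the source may bear on it.

Compound 1 `Nc1ncnc2c1nc(NCCCCCCCCNC(=O)CI)n2[C@@H]1O[C@H](COP(=O)(O)OP(=O)(O)OP(=O)(O)O)[C@@H](O)[C@H]1O` is one of two measured compounds built on a shared core bearing a triphosphate and a saturated chain that ends in a ((iodomethyl)carbonyl)amino group. In an assay on isolated protein for inhibition of hexokinase-2 (Rattus norvegicus), with a stated time of 6 h, tested at 10 mM (on this read-out higher numbers stand for more inhibition at the one concentration tested (going by the name of the read-out) and lower numbers for less inhibition), compound 1 gives 0%. Compound 2 `O=C(CI)NCCCCNc1ncnc2c1ncn2[C@@H]1O[C@H](COP(=O)(O)OP(=O)(O)OP(=O)(O)O)[C@@H](O)[C@H]1O`, which carries a shorter chain attached to a different nitrogen of the core, is measured in this assay at 0%. Compound 1 thus stands level with compound 2 at the digits shown, and the two numbers agree within the scatter, so no order between them can be read. Compound 3 `Nc1ncnc2c1nc(NCCNC(=O)CI)n2[C@@H]1O[C@H](COP(=O)(O)OP(=O)(O)OP(=O)(O)O)[C@@H](O)[C@H]1O` has not been measured. It differs from compound 1 in one place: ((iodomethyl)carbonyl)amino in place of 6-(((iodomethyl)carbonyl)amino)hexyl on a saturated chain carbon, two bonds along the chain from a nitrogen on an aromatic ring. Because compound 1 gives 0% and compound 2 gives 0%, no step beyond the scatter is expected in this assay from this shortening. The expected step is a number 2 percentage points higher from compound 1 to compound 3 (within the scatter). Compound 3 is expected to give 2%, within a range from -8% to 15%.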

Compound 3, a percentage reported as inhibition, at one concentration (the size of the read-out at that concentration, not a potency): 0%
The estimate for compound 3 lay 2 percentage points above the measured number; low and high end bracket the measured number.
By their numbers in this assay, from the lowest: compounds 1, 2 and 3 (each within the scatter of the next).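

In this assay, putting ((iodomethyl)carbonyl)amino in place of 6-(((iodomethyl)carbonyl)amino)hexyl, on a saturated chain carbon, two bonds along the chain from a nitrogen on an aromatic ring, gives no change at the digits printed from compound 1 to compound 3 (within the scatter). Within the data shown here, this is the first comparison in which chain length alone differs, and at this position the long and the short chain cannot be told apart on this read-out. No supporting data bear on this result.

Going by these compounds, what stays open is whether any group at this position can produce inhibition in this assay. An amine or a carboxylic acid at the end of the chain, in place of the ((iodomethyl)carbonyl)amino group, would test whether the chain end matters, and a chain longer than that of compound 1 would extend the length comparison.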